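Catechol in place of anisole on a cyclohexanone dienone core

A few compounds are considered here, and "the series" means these few. Any claim that something is new, unique, unknown or untested is made for them only; others in the source may bear on it.

Compound 1: `COc1ccc(/C=C2\CCC/C(=C\c3cccc(OC)c3OC)C2=O)cc1` — > 20000 nM
Compound 2: `COc1ccc(/C=C2\CCC/C(=C\c3cccc(OC)c3OC)C2=O)c(OC)c1` — > 20000 nM
Compound 3: `COc1cccc(/C=C2\CCC/C(=C\c3ccc(O)c(O)c3)C2=O)c1OC` — not yet measured

In a functional assay on A549 cells (Homo sapiens) for cytotoxicity, read by MTT assay, with a stated time of 72 h (a lower number here means a stronger inhibitor, a higher number a weaker inhibitor), compound 1 gives only a limit, > 20000 nM. Compound 2 likewise gives only a limit, > 20000 nM. Both values sit at the limit of > 20000 nM in this assay, at which 2 of the 2 values shown sit, so the step from compound 1 to compound 2 cannot be read: a step that the two limits leave unreadable from compound 1 to compound 2, which is the change of methoxy in place of hydrogen on an aromatic carbon.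

Compound 3 differs from compound 1 by 3,4-dihydroxyphenyl in place of 4-methoxyphenyl on a double-bonded chain carbon bound to a double-bonded ring carbon. For the measured compounds named here, no measured step bears on this change: the only step recorded is the one from compound 1 to compound 2, and it is unreadable. The expectation for compound 3 in this assay therefore rests on compound 1 alone, whose value is a limit, and the estimated step that the limit leaves unreadable from compound 1 to compound 3 is taken as none beyond the scatter, with the outcome most likely again a limit. The estimate for compound 3 is 25000 nM, within a range from 7000 nM to 80000 nM.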

Compound 3, half-maximal inhibitory concentration: > 20000 nM
Compound 3 gave a limit, no number; the forecaster's own chance of this, stated with the estimate: 65%; the middle value is on the limit's open side.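

In this assay compound 3, like compound 1, gives only a limit, so the step between compound 1 and compound 3 cannot be read: the limit of > 20000 nM in this assay, at which 3 of the 3 values shown sit.

The compounds shown leave open whether 3,4-dihydroxyphenyl in place of 4-methoxyphenyl has any effect in this assay, and how the three compounds would rank there.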